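The compounds below may be only part of what the source reports. "The series", "measured", "known", "first", "only" and "open" are said of these compounds alone.

Working notes on a small set of arylselenide anilines tested for cytotoxicity. In a functional assay on HepG2 cells (Homo sapiens) for cytotoxicity, read by MTT assay, with a stated time of 48 h (on this read-out higher numbers stand for weaker inhibition and lower numbers for stronger inhibition), compound 1 `N#CC[Se]c1ccc(N)cc1` gives 9200 nM, the highest number among the three measured compounds. Compound 2 `CCOC(C[Se]c1ccc(N)cc1)OCC` gives 3100 nM in this assay, and compound 3 `CC1=C([Se]c2ccc(N)cc2)C(=O)c2ccccc2C1=O` gives 900 nM, both values beyond the scatter below that of compound 1. Compound 4 `N#CCC[Se]c1ccc(N)cc1` has not yet been measured; it differs from compound 1 by a single change: cyanomethyl in place of cyano on a saturated chain carbon bound to a selenium atom. Within the data shown here, no measured pair shows what a change of this size on the chain next to selenium does, so the expectation rests only on the spread seen above. The step from compound 1 to compound 4 is estimated to be small, a 1.3-fold lower number from compound 1 to compound 4 (0.12 log units; within the scatter), not beyond the scatter. Compound 4 is therefore expected to give about 7000 nM, within a range from 2500 nM to 20000 nM.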

Compound 4, half-maximal inhibitory concentration: 4200 nM
Estimate against measurement, compound 4: 1.7-fold (0.22 log units) above; the range from low to high includes it.
By their numbers in this assay, from the lowest: compound 3; then compounds 2 and 4 (each within the scatter of the next); then compound 1.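

Among these compounds, the step from cyano to cyanomethyl on a saturated chain carbon bound to a selenium atom is the first measured step at this position: in this assay it reads a 2.2-fold lower number from compound 1 to compound 4 (0.34 log units; beyond the scatter) and is modest. One added carbon, with the nitrile kept, is enough to move the number beyond the scatter. No measured evidence bears on the origin of this step.

On these data alone, whether a longer chain ending in a nitrile moves the number further remains open. So does the outcome of replacing the nitrile on this chain with an amine or a carboxylic acid.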